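From methyl to cyclohexyl on compound 1

The source may report more compounds than this note shows. Statements on the series, on what has been measured and on what is new or still open speak of the compounds shown alone.

In a functional assay on brain (Rattus norvegicus, strain Wistar) for inhibition (a higher number here means a weaker inhibitor, a lower number a stronger inhibitor), compound 1 `Cc1[nH]c(=O)n(C)c1-c1ccc(OCCC(C)C)cc1` gives 6600 nM, compound 2 `CCCCCCOc1ccc(-c2c(C)[nH]c(=O)n2C)cc1` gives 7300 nM and compound 3 `CCCCCCCc1ccc(-c2c(C)[nH]c(=O)n2C)cc1` gives 8400 nM. These three numbers all lie within the usual scatter of one another, so compound 1 stands level with its two relatives.

The three compounds differ only in their long chain, and the steps between them are small. Butyl in place of isopropyl gives a 1.1-fold higher number from compound 1 to compound 2 (0.04 log units; within the scatter), heptyl in place of isopentyloxy gives a 1.3-fold higher number from compound 1 to compound 3 (0.10 log units; within the scatter), and heptyl in place of hexyloxy gives a 1.2-fold higher number from compound 2 to compound 3 (0.06 log units; within the scatter).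

Compound 4 `Cc1[nH]c(=O)n(C2CCCCC2)c1-c1ccc(OCCC(C)C)cc1` keeps the chain of compound 1 and differs elsewhere, with cyclohexyl in place of methyl on an aromatic nitrogen. Within the data shown here, none of the measured steps touches that nitrogen, so they offer no direct guide to this change and point in no direction. Among the measured compounds shown here, they show only that the chain swaps stayed within the scatter.

The best guess is therefore no step beyond the scatter, though a real shift either way remains possible, and the expected change is a 1.3-fold lower number from compound 1 to compound 4 (0.12 log units; within the scatter). For compound 4 the estimated value is 5000 nM, with an expected range from 1000 nM to 25000 nM.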

Compound 4, half-maximal inhibitory concentration: 7200 nM
Estimate against measurement, compound 4: 1.4-fold (0.16 log units) below, within the range that was stated.
By their numbers in this assay, from the lowest: compounds 1, 4, 2 and 3 (each within the scatter of the next).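

At this aromatic nitrogen, cyclohexyl in place of methyl brings six heavy atoms and a six-membered non-aromatic ring where one carbon stood, yet this assay shows only a 1.1-fold higher number from compound 1 to compound 4 (0.04 log units; within the scatter). Among these compounds, the earlier steps all changed the long chain, so this is the first reading at the nitrogen of the five-membered ring, and it shows that a much bigger carbon-only group can sit there without moving the number beyond the scatter. No measurement shown here explains why the number holds steady across this change.

Cyclohexyl and methyl both contain carbon only, so it remains open whether a group with other atoms on this nitrogen, such as an aminoethyl group or a carboxymethyl group, or simply a hydrogen in place of the methyl, would give a step beyond the scatter. On these data alone, it also remains open whether cyclohexyl on this nitrogen would give the same small step alongside the hexyloxy chain of compound 2 or the heptyl chain of compound 3.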